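A few compounds are considered here, and "the series" means these few. Any claim that something is new, unique, unknown or untested is made for them only; others in the source may bear on it.

Measured so far in a functional assay on SiHa cells (Homo sapiens) for cytotoxicity, read by MTT assay, with a stated time of 48 h; a lower number here means a stronger inhibitor, a higher number a weaker inhibitor:
compound 1 `CCCCCCCCCCCCNC(=O)[C@@H](NC(=O)c1cc2ccccc2[nH]1)[C@@H](C)O`: 21300 nM
compound 2 `CCCCCCCCCCCCNC(=O)[C@@H](NC(=O)c1cc2ccccc2n1C)[C@@H](C)O`: compound 2 gives a limit, > 200000 nM
compound 3 `CCCCCCCCCCCCCCCCCCNC(=O)[C@@H](NC(=O)c1cc2ccccc2[nH]1)[C@@H](C)O`: 29600 nM

Compound 2 differs from compound 1 by methyl in place of hydrogen on an aromatic nitrogen, and the step is an at least 9.3-fold higher number from compound 1 to compound 2 (0.97 log units; beyond the scatter); the value of compound 2 is a limit, (the limit of > 200000 nM in this assay, at which 1 of the 3 values shown sits). The cores of compound 1 and compound 3 differ by hexyl in place of hydrogen on a saturated chain carbon, ten or more bonds along the chain from an amide-type nitrogen, a step of a 1.4-fold higher number from compound 1 to compound 3 (0.14 log units; within the scatter). Compound 4 `CCCCCCCCCCCCCCCCCCNC(=O)[C@@H](NC(=O)c1cc2ccccc2n1C)[C@@H](C)O` is not yet measured; it differs from compound 3 by methyl in place of hydrogen on an aromatic nitrogen, the same change as from compound 1 to compound 2. For compound 4 the expected step is a 10-fold higher number from compound 3 to compound 4 (1.01 log units; beyond the scatter), resting on the change from compound 1 to compound 2 an at least 9.3-fold higher number from compound 1 to compound 2 (0.97 log units; beyond the scatter). Compound 4 is expected to give roughly 300000 nM, estimated between 100000 nM and 1000000 nM, most likely reported only as a limit.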

Compound 4, half-maximal inhibitory concentration: 113000 nM
Beside the measured number, compound 4's estimate is 2.7-fold (0.42 log units) above it; the measured number falls inside the stated range.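

In this assay the step for methyl in place of hydrogen on an aromatic nitrogen is a 3.8-fold higher number from compound 3 to compound 4 (0.58 log units; beyond the scatter) and points the same way as on the core of compound 1, so the direction of the change carries over between these two cores. Whether its size carries over is not shown: the same change on two cores in this assay, an at least 9.3-fold higher number (0.97 log units; beyond the scatter) from compound 1 to compound 2 and a 3.8-fold higher number (0.58 log units; beyond the scatter) from compound 3 to compound 4; the limit leaves it open whether they differ. For hexyl in place of hydrogen on a saturated chain carbon the further step is an at least 1.7-fold lower number from compound 2 to compound 4 (0.24 log units; that floor lies within the scatter) and gives no firmer reading of that change: the same change on two cores in this assay, a 1.4-fold higher number (0.14 log units; within the scatter) from compound 1 to compound 3 and an at least 1.7-fold lower number (0.24 log units; that floor lies within the scatter) from compound 2 to compound 4; the limit leaves it open whether they differ.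

Open, going by these compounds, is whether a group larger than methyl on the aromatic nitrogen, such as ethyl, would follow the same course. Also open, on these data alone, is what an amine or a carboxylic acid at the end of the chain would do to either step.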